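The source may report more compounds than this note shows. Statements on the series, on what has been measured and on what is new or still open speak of the compounds shown alone.

Of the compounds shown here, two with a shared core have been tested in an ADME assay for solubility; on this read-out lower numbers stand for lower solubility and higher numbers for higher solubility. Compound 1 `CCCN(C)C(=O)COC(=O)/C=C/c1ccc(NC(=O)C2(NC(=O)c3ccc4c(C5CCCC5)c(-c5ncc(Cl)cn5)n(C)c4c3)CCC2)cc1OCC` carries a propyl group on an amide-type nitrogen. In this assay compound 1 gives < 200000 ug/mL, which is a limit of the assay rather than a number. Compound 2 `CCOc1cc(NC(=O)C2(NC(=O)c3ccc4c(C5CCCC5)c(-c5ncc(Cl)cn5)n(C)c4c3)CCC2)ccc1/C=C/C(=O)OCC(=O)N(C)C(C)C` differs only by having isopropyl in place of propyl on that nitrogen. In this assay compound 2 also gives < 200000 ug/mL, again a limit. The step that the two limits leave unreadable from compound 1 to compound 2 therefore cannot be read, since both values sit at the limit of < 200000 ug/mL in this assay, at which 2 of the 2 values shown sit.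

Compound 3 `CCOc1cc(NC(=O)C2(NC(=O)c3ccc4c(C5CCCC5)c(-c5ncc(Cl)cn5)n(C)c4c3)CCC2)ccc1/C=C/C(=O)OCC(=O)N1CCCC1` has not been measured. It differs from compound 2 by pyrrolidin-1-yl in place of isopropyl(methyl)amino on a carbonyl carbon. Only the unreadable step from compound 1 to compound 2 bears on this change, so no size or direction can be drawn from it. Compound 3 is expected to give 150000 ug/mL (range 50000 ug/mL to 200000 ug/mL), most likely again reported as a limit, which means an expected step that the limit leaves unreadable from compound 2 to compound 3.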

Compound 3, solubility: 200000 ug/mL
The estimate for compound 3 lay 1.3-fold (0.12 log units) below the measured number, within the range that was stated.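

Among these compounds, at this carbonyl carbon, pyrrolidin-1-yl gives the first actual number in this assay, whereas the earlier compounds gave only limits. Replacing isopropyl(methyl)amino with this ring, which has the same count of heavy atoms, reads as a number no lower from compound 2 to compound 3 (the limit leaves the size open), and replacing methyl(propyl)amino reads as a number no lower from compound 1 to compound 3 (the limit leaves the size open). These steps give a direction only, and their size stays open because the values of the earlier compounds are limits: the limit of < 200000 ug/mL in this assay, at which 2 of the 3 values shown sit.

The compounds shown hold only one ring at this place, so they cannot tell whether a piperidin-1-yl or morpholin-4-yl group would read the same way. They also leave open whether an open-chain group such as dimethylamino would give a number here rather than a limit.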